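From diethylamino to (3-(dimethylamino)propyl)(methyl)amino

The source may hold more compounds than are shown below. What is called first, only, known or untested is meant among the compounds shown, and "the series" means these compounds.

In a functional assay on MCF7 cells (Homo sapiens) for antiproliferative activity, with a stated time of 72 h (a higher number here means a weaker inhibitor, a lower number a stronger inhibitor), compound 1 `COC(=O)CN(C)Cc1c(OC)cc(OC)c(C(=O)/C=C/c2ccccc2Cl)c1O` gives 10600 nM and compound 2 `COc1cc(OC)c(C(=O)/C=C/c2ccccc2Cl)c(O)c1CN(C)CC(=O)O` gives 73200 nM while compound 3 `CCN(CC)Cc1c(OC)cc(OC)c(C(=O)/C=C/c2ccccc2Cl)c1O` gives 2700 nM as the lowest number of the three. Compound 4 `COc1cc(OC)c(C(=O)/C=C/c2ccccc2Cl)c(O)c1CN(C)CCCN(C)C` keeps the shared core and differs from compound 3 in one place, with (3-(dimethylamino)propyl)(methyl)amino in place of diethylamino on a saturated chain carbon bound to an aromatic carbon as the change.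

For the measured compounds named here, two measured steps touch that same place. Replacing ((methoxycarbonyl)methyl)(methyl)amino with diethylamino gave a 3.9-fold lower number from compound 1 to compound 3 (0.59 log units; beyond the scatter) as a modest move, and replacing (carboxymethyl)(methyl)amino with diethylamino gave a 27-fold lower number from compound 2 to compound 3 (1.43 log units; beyond the scatter) as a large one. Neither step involves the entering chain, so neither gives a direction for it. Like compound 3, compound 4 carries neither of those two groups. The step expected is a 1.1-fold lower number from compound 3 to compound 4 (0.03 log units; within the scatter) and so none beyond the scatter. Going by these compounds, the entering chain is untested, which leaves the range wide. Compound 4 is estimated at 2500 nM with an expected range from 800 nM to 8000 nM in this measurement.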

Compound 4, half-maximal inhibitory concentration: 3200 nM
For compound 4 the middle estimate is 1.3-fold (0.11 log units) below the measured one, within the range that was stated.
By their numbers in this assay, from the lowest: compounds 3 and 4 (each within the scatter of the next); then compound 1; then compound 2.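

In this assay, (3-(dimethylamino)propyl)(methyl)amino in place of diethylamino gave a 1.2-fold higher number from compound 3 to compound 4 (0.07 log units; within the scatter), so at this place, on a saturated chain carbon bound to an aromatic carbon, the larger group of 8 heavy atoms with its second nitrogen reads the same as the group of 5 heavy atoms. The same chain sets compound 4 well apart from the other two compounds: 2-(dimethylamino)ethyl in place of carboxy gave a 23-fold lower number from compound 2 to compound 4 (1.36 log units; beyond the scatter), and in place of methoxycarbonyl it gave a 3.3-fold lower number from compound 1 to compound 4 (0.52 log units; beyond the scatter). No measurement shown here accounts for these steps.

The compounds shown leave open whether an amine held in a ring, such as piperidine or morpholine, would read the same at this place. They also leave open what a shorter or longer chain between the two nitrogens would give.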